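The compounds below may be only part of what the source reports. "The series", "measured", "known", "first", "only" and "open" are said of these compounds alone.

Measured compounds:
Compound 1, `CCCCc1cnc(C(C)Cc2ccc(-c3ccccc3C(=O)O)cc2)[nH]1`, gives 184 nM.
Compound 2, `CCCCc1cnc(CCCc2ccc(-c3ccccc3C(=O)O)cc2)[nH]1`, gives 382 nM.
Compound 3, `N#Cc1ccc(Cc2cnc(CCc3ccc(-c4ccccc4C(=O)O)cc3)[nH]2)cc1`, gives 723 nM.

All three values come from an in vitro functional assay on cells for agonist activity at Bombesin receptor subtype-3 (Mus musculus), read by luminescence and calcium flux; on this read-out lower numbers stand for an effect already at smaller amounts and higher numbers for an effect only at larger amounts of compound. Compound 3 stands at the highest of the three numbers. Its gap to compound 2 lies within the usual scatter of repeated measurements, so those two cannot be told apart. Its gap to compound 1 lies beyond the scatter, so compound 3 needs clearly more material than compound 1 to reach the same effect.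

Compound 4, `CCC(C)(CC)Cc1cnc(CCc2ccc(-c3ccccc3C(=O)O)cc2)[nH]1`, has not yet been measured. It differs from compound 3 in one place: 1-ethyl-1-methylpropyl in place of 4-cyanophenyl on a saturated chain carbon bound to an aromatic carbon. An aromatic ring carrying a nitrile goes out, and a branched, saturated group with no ring and no hydrogen-bond acceptor comes in.

The two compounds that already carry an open saturated chain rather than an aromatic ring in that region sit at the lower numbers: compound 1 gives 184 nM and compound 2 gives 382 nM. On that basis the step from compound 3 to compound 4 is expected to lower the number, and the estimated step is a 2.6-fold lower number from compound 3 to compound 4 (0.41 log units; beyond the scatter), a drop somewhat beyond the scatter. Compound 4 is therefore expected to reach 280 nM, in a range from 90 nM to 900 nM.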

Compound 4, half-maximal effective concentration: 30 nM
The estimate for compound 4 lay 9.3-fold (0.97 log units) above the measured number; the measured number lies below the stated range.
By their numbers in this assay, from the lowest: compound 4; then compound 1; then compounds 2 and 3 (each within the scatter of the next).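

In this assay the exchange of 4-cyanophenyl for 1-ethyl-1-methylpropyl gives a 24-fold lower number from compound 3 to compound 4 (1.38 log units; beyond the scatter) and this large drop shows that this place, on a saturated chain carbon bound to an aromatic carbon, needs neither an aromatic ring nor a nitrile for the effect to appear at small amounts. Of the two groups compared here, the branched, saturated one with no ring and no hydrogen-bond acceptor gives the lower number, even though it has fewer heavy atoms than the group it replaces, so a larger group is not required at this place. Nothing measured here explains why the number falls so far.

This single exchange alters the ring, the nitrile and the branching all at once, so the compounds shown cannot tell which of these changes accounts for the step. Going by these compounds, a plain phenyl in place of 4-cyanophenyl, or a cyclohexyl ring or a straight hexyl chain in place of 1-ethyl-1-methylpropyl, would separate these changes, and whether a tert-butyl group or an amine at this place would keep the number low also stays open.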